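The compounds below may be only part of what the source reports. "The series", "measured", "known", "first", "only" and "open" are said of these compounds alone.

Measured so far in an ADME assay for permeability, using PAMPA, with a stated time of 4 h, at pH 5.5; on this read-out lower numbers stand for lower permeability and higher numbers for higher permeability:
compound 1 `NCCCCN(C[C@@H]1Cc2ncccc2CN1)[C@H]1CCCc2cccnc21` gives 2 nm/s
compound 2 `NCCCCN(C[C@@H]1Cc2cccnc2CN1)[C@H]1CCCc2cccnc21` stands as "not determined" (no result reported)
compound 3 `NC(=O)NC/C=C/CN(C[C@H]1Cc2ncccc2CN1)[C@H]1CCCc2cccnc21` gives 6 nm/s

Among the compounds with values here, only two numbers are available for this series. Compound 3 stands higher of the two, and its gap to compound 1 lies beyond the usual scatter. With compound 2 unreported, the comparison cannot be widened.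

The next compound to be read is compound 4 `c1cnc2c(c1)CN[C@@H](CN(CCCCNC1COC1)[C@H]1CCCc3cccnc31)C2`. Relative to compound 3, the structural change is a group of 8 heavy atoms (6 carbon, 1 nitrogen, 1 oxygen; one four-membered non-aromatic ring with 1 hetero atom) in place of a group of 7 heavy atoms (4 carbon, 2 nitrogen, 1 oxygen; no ring), on a saturated chain carbon bound to an amine nitrogen. It brings in a four-membered non-aromatic ring with 1 hetero atom, while the group that leaves has no ring.

Within the data shown here, no measured pair isolates this change, so the size of the step cannot be read from precedent. Among the measured compounds shown here, the only guide is the spread of the two known numbers, compound 1 at 2 nm/s and compound 3 at 6 nm/s. Compound 4 is expected to fall within that general region, with a slight fall at most and no firm direction. The estimated change is a 1.2-fold lower number from compound 3 to compound 4 (0.08 log units; within the scatter), which is not expected to lie beyond the scatter. In this assay the estimate for compound 4 is 5 nm/s, with an expected range of 1.5 nm/s to 18 nm/s as its limits.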

Compound 4, apparent permeability: 7 nm/s
For compound 4 the middle estimate is 1.4-fold (0.15 log units) below the measured one; measured number inside the range.
By their numbers in this assay, from the lowest: compound 1; then compounds 3 and 4 (each within the scatter of the next).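

In this assay, within the data shown here, the exchange on a saturated chain carbon bound to an amine nitrogen gives the first readable step: a 1.2-fold higher number from compound 3 to compound 4 (0.07 log units; within the scatter). The group that leaves has no ring, 2 double bonds outside aromatic rings, 2 hydrogen-bond donors and 1 hydrogen-bond acceptor; the group that enters has one four-membered non-aromatic ring with 1 hetero atom, 1 hydrogen-bond donor and 2 hydrogen-bond acceptors, and this full exchange leaves the two compounds within the scatter of each other. No measurement shown gives a reason for this outcome.

This single pair cannot separate the contribution of the four-membered ring from that of the remaining differences between the two groups, so it sets no rule for the position. On these data alone, how this assay responds to a carboxylic acid, a morpholine ring or a longer chain at this place remains open, as does whether the exchange gives a similar step on other cores.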